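This account rests on a few compounds, and the source may have more. Where it says the series, first, only, none or still open, it means among the compounds named here.

In a functional assay for inhibition, with Rattus norvegicus as the target (on this read-out higher numbers stand for weaker inhibition and lower numbers for stronger inhibition), compound 1 (`CC(C)(C)C/N=c1\c(O)c(O)\c1=N/c1ccc(C#N)cc1`) reaches only a limit, > 30000 nM in that case. Going by the values given here, compound 2 (`CC(C)/N=c1\c(O)c(O)\c1=N/c1ccc(C#N)cc1`) gives 13700 nM as the only actual number so far. Compound 3 (`C[C@@H](/N=c1\c(O)c(O)\c1=N/c1ccc(C#N)cc1)c1ccccc1`) differs from it by 1-phenylethyl in place of isopropyl on a double-bonded nitrogen with 1-phenylethyl in place of isopropyl on a double-bonded nitrogen. Among the compounds with values here, the sole measured step bearing on this is an at least 2.1-fold lower number from compound 1 to compound 2 (0.34 log units; beyond the scatter) with isopropyl in place of neopentyl at that nitrogen. Neither of those groups holds a ring, so no clear direction follows, and no step beyond the scatter is expected in this assay. The estimated step is a 1.4-fold lower number from compound 2 to compound 3 (0.14 log units; within the scatter) for now. For compound 3 the expected value is 10000 nM within an estimated range of 2000 nM to 40000 nM overall.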

Compound 3, half-maximal inhibitory concentration: 56 nM
Compound 3: middle estimate off by 180-fold (2.25 log units), on the high side; measured number below the stated range.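

Going by these compounds alone, on the double-bonded nitrogen, the earlier compounds carried only groups without a ring, and in this assay 1-phenylethyl in place of isopropyl now gives a 240-fold lower number from compound 2 to compound 3 (2.39 log units; beyond the scatter). Set against neopentyl, the same group gives an at least 530-fold lower number from compound 1 to compound 3 (2.72 log units; beyond the scatter). That second step is only a bound, as compound 1 stands at a limit: the limit of > 30000 nM in this assay, at which 1 of the 3 values shown sits.

As far as these compounds go, whether a cyclohexyl or a benzyl group on this nitrogen would give a similar step remains open. So does what the opposite stereoisomer of 1-phenylethyl would give.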